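A few compounds are considered here, and "the series" means these few. Any claim that something is new, unique, unknown or untested is made for them only; others in the source may bear on it.

Compound 1 `COC(=O)c1ccc(NCc2cncn2Cc2ccc(Cl)cc2)cc1-c1ccccc1` — 25000 nM
Compound 2 `COC(=O)c1ccc(NCc2cncn2Cc2ccc(C(C)(C)C)cc2)cc1-c1ccccc1` — "not determined" (no result reported)
Compound 3 `COC(=O)c1ccc(NCc2cncn2Cc2cccc(OC)c2)cc1-c1ccccc1` — "not determined" (no result reported)

The series shares one core, and only the group on the benzyl arm changes. In a toxicity assay on NIH3T3 cells (Mus musculus) for cytotoxicity, read by resazurin assay (on this read-out lower numbers stand for an effect already at smaller amounts and higher numbers for an effect only at larger amounts of compound), compound 1 gives 25000 nM. For compound 2 the entry in this assay reads "not determined" (no result reported), and for compound 3 the entry in this assay likewise reads "not determined" (no result reported); compound 3 therefore stands without a single number, and compound 2 is the one further entry in the same state.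

Compound 4 `COC(=O)c1ccc(NCc2cncn2Cc2ccccc2)cc1-c1ccccc1` is the next member and is to be measured in this assay. It differs from compound 3 in one place, (hydrogen in place of methoxy on an aromatic carbon), the carbon being on a six-membered aromatic ring of carbon only.

Since no number exists for compound 3, no step from compound 3 to compound 4 can be sized; no step beyond the usual scatter is expected for a change of this kind in this assay. Because compound 1 gives 25000 nM in this assay, compound 4 is expected at 30000 nM, estimated between 10000 nM and 90000 nM.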

Compound 4, half-maximal effective concentration: > 1000 nM
Compound 4: only a limit was reported; the forecaster's own chance of this, stated with the estimate: 40%; the middle value lies beyond the limit too.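

Going by these compounds alone, compound 4 carries only a limit, not a number, in this assay, so no step from compound 1 to compound 4 can be read: the limit of > 1000 nM in this assay, at which 1 of the 4 values shown sits.

The compounds shown leave open whether hydrogen in place of chloro or methoxy on the benzyl arm changes the result in this assay at all.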